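Three Analogues at the Toxicity Limit, a Fourth Expected There

A few compounds are considered here, and "the series" means these few. Any claim that something is new, unique, unknown or untested is made for them only; others in the source may bear on it.

Compound 1, `COc1ccc([C@H]2CC(=O)N(Cc3cccc(C#N)c3)C2)cc1OC1CCCC1`: > 10000 nM
Compound 2, `COc1ccc([C@H]2CC(=O)N(C(C)=O)C2)cc1OC1CCCC1`: > 10000 nM
Compound 3, `COc1ccc([C@H]2CC(=O)N(c3cccc(N(C)C)c3)C2)cc1OC1CCCC1`: > 10000 nM

All three measured compounds share one core and differ only in the group on the amide-type nitrogen in the ring. In a functional assay on HEK293 cells (Homo sapiens) for cytotoxicity (on this read-out higher numbers stand for lower toxicity in this test and lower numbers for higher toxicity in this test), compound 2 gives > 10000 nM, which is a limit of the assay and not a number. The same holds for compound 1 and compound 3, so compound 2 stands level with both as far as the figures show, and (the limit of > 10000 nM in this assay, at which 3 of the 3 values shown sit). The steps a step that the two limits leave unreadable from compound 1 to compound 2, a step that the two limits leave unreadable from compound 1 to compound 3 and a step that the two limits leave unreadable from compound 2 to compound 3 cannot be sized; they only show that swapping a benzyl, an acetyl or a phenyl group on that nitrogen brings no toxicity into view.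

Compound 4, `COc1ccc([C@H]2CC(=O)N(c3ccc(N)cc3)C2)cc1OC1CCCC1`, is not yet measured. The change from compound 2 is 4-aminophenyl in place of acetyl on an amide-type nitrogen in a ring. It resembles the step to compound 3, which also put an aromatic ring on that nitrogen without a readable change. No step beyond the scatter is therefore expected, and compound 4 is estimated at 15000 nM in this assay, within 5000 nM to 50000 nM, an expected step that the limit leaves unreadable from compound 2 to compound 4.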

Compound 4, half-maximal cytotoxic concentration: > 10000 nM
Compound 4: no number, only a limit; the forecaster's own chance of this, stated with the estimate: 85%; the middle value is on the limit's open side.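

In this assay compound 4 gives > 10000 nM, which is a limit of the assay and not a number. Among these compounds, no step from compound 1, compound 2 or compound 3 to compound 4 can be read. The compounds shown leave open whether any group on that nitrogen would bring toxicity into view, and how the four compounds truly compare.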